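The compounds below may be only part of what the source reports. "The series", "measured", "known", "first", "only" and "open" are said of these compounds alone.

Working notes on the series, all measured in an assay on isolated protein for binding affinity to 5-hydroxytryptamine receptor 3A (Homo sapiens); a lower number here means a stronger inhibitor, a higher number a weaker inhibitor. Of the compounds shown here, three have numbers so far. Compound 1 `CS(=O)(=O)N1CCN(CC(O)CN2CCC(NC(=O)c3cccc4[nH]cnc34)CC2)CC1` gives 63100 nM. Compound 2 `CC(C)c1nc2c(C(=O)NCC3CCN(CCN4CCN(S(C)(=O)=O)CC4)CC3)cccc2[nH]1` gives 100000 nM. Compound 3 `COC(=O)N1CCN(CCN2CCC(CNC(=O)c3cccc4[nH]c(C(C)C)nc34)CC2)CC1` gives 79400 nM. Compound 3 holds the second highest of the three numbers, and both of its neighbours sit within the scatter: compound 1 on one side and compound 2 on the other, so no ordering among the three can be read from these values.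

One step joins compounds that differ in a single place, and it was a 1.3-fold lower number from compound 2 to compound 3 (0.10 log units; within the scatter), a change of methoxycarbonyl in place of methylsulfonyl on an amine nitrogen in a ring.

Compound 4 `CC(=O)N1CCN(CCN2CCC(CNC(=O)c3cccc4[nH]c(C(C)C)nc34)CC2)CC1` is not yet measured. It differs from compound 3 by methyl in place of methoxy on a carbonyl carbon. Among the measured compounds shown here, the only step that bears on this position is the one from compound 2 to compound 3, which also swapped the group carried by the same amine nitrogen in a ring and stayed within the scatter. On that basis a further swap at the same place is expected to leave this assay essentially unchanged, with no step beyond the scatter in either direction. For compound 4 the expected step is a 1.1-fold lower number from compound 3 to compound 4 (0.02 log units; within the scatter). Compound 4 is therefore estimated at 75000 nM, within a range from 25000 nM to 200000 nM.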

Compound 4, inhibition constant: 39800 nM
Estimate against measurement, compound 4: 1.9-fold (0.28 log units) above, within the range that was stated.
By their numbers in this assay, from the lowest: compounds 4, 1, 3 and 2 (each within the scatter of the next, the first and the last beyond it).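

In this assay, among the compounds shown here, the group carried by this amine nitrogen in a ring now gives a step beyond the scatter for the first time: a 2.5-fold lower number from compound 2 to compound 4 (0.40 log units; beyond the scatter), with acetyl in place of methylsulfonyl, whereas methoxycarbonyl in place of methylsulfonyl gave only a 1.3-fold lower number from compound 2 to compound 3 (0.10 log units; within the scatter). The change of methyl in place of methoxy on the carbonyl carbon gives a 2.0-fold lower number from compound 3 to compound 4 (0.30 log units; within the scatter), so acetyl and methoxycarbonyl cannot be ordered at this position, and only the acetyl comparison with methylsulfonyl can be read as a real, though modest, difference. Compound 4 still gives 39800 nM in this assay, and nothing available here bears on what lies behind the step.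

The compounds shown leave open how this position responds to groups other than methylsulfonyl, methoxycarbonyl and acetyl, such as a longer acyl chain, a carboxylic acid or a simple amine. They also leave open whether acetyl in place of methylsulfonyl gives a similar step on the core of compound 1, since acetyl appears here only on the core of compound 4.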